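Swapping fluoro for methoxy on the aryl ring

This account rests on a few compounds, and the source may have more. Where it says the series, first, only, none or still open, it means among the compounds named here.

Compound 1 `CSc1ccc(C)cc1NCC1=NCCN1`: 0.912 nM
Compound 2 `CSc1ccc(F)cc1NCC1=NCCN1`: 21.9 nM

In a functional assay for agonist activity at Alpha-1D adrenergic receptor (Homo sapiens) (a higher number here means that more compound is needed for the effect, a lower number that less compound is needed), compound 2 gives 21.9 nM, the highest of the two numbers; its nearest neighbour is compound 1, which gives 0.912 nM. For the measured compounds named here, the only measured step, a 24-fold higher number from compound 1 to compound 2 (1.38 log units; beyond the scatter), is large, so the group at this position, para to a methylsulfanyl group, matters a great deal. Compound 3 `COc1ccc(SC)c(NCC2=NCCN2)c1` differs from compound 2 by methoxy in place of fluoro on an aromatic carbon. Going by the values given here, no measured step covers methoxy directly; the fluoro-to-methyl step is the only guide. A methoxy group, like methyl, carries a carbon at this position, so compound 3 is expected to give a number between those of compound 2 and compound 1, nearer the latter, meaning a 7.3-fold lower number from compound 2 to compound 3 (0.86 log units; beyond the scatter) is expected. Compound 3 is estimated at 3 nM, within 0.7 nM to 15 nM.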

Compound 3, half-maximal effective concentration: 5.01 nM
Compound 3: the middle estimate sits 1.7-fold (0.22 log units) below what was measured; the range from low to high includes it.
By their numbers in this assay, from the lowest: compound 1; then compound 3; then compound 2.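

In this assay, the position para to a methylsulfanyl group now carries three different groups, and methoxy falls in the middle of the series: replacing fluoro gives a 4.4-fold lower number from compound 2 to compound 3 (0.64 log units; beyond the scatter), while replacing methyl gives a 5.5-fold higher number from compound 1 to compound 3 (0.74 log units; beyond the scatter). Both steps lie beyond the usual scatter, so the order from the lowest number is methyl, methoxy, fluoro, and methoxy matches neither neighbour, even though it shares a carbon with methyl and adds an oxygen. Nothing available explains this order.

Three groups at one position cannot show what would happen with an amine, a hydroxy group or a longer chain such as ethoxy. As far as these compounds go, it also remains open whether this order would hold at another position on the ring.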